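This account rests on a few compounds, and the source may have more. Where it says the series, first, only, none or still open, it means among the compounds named here.

The shared core carries a bis(trifluoromethyl)phenyl sulfonamide linked through a short amine chain to a benzyl group. Compound 1 `O=S(=O)(NCCCNCc1ccccc1)c1cc(C(F)(F)F)cc(C(F)(F)F)c1` is the unsubstituted benzyl parent; in a functional assay on HPAC cells (Homo sapiens) for inhibition, read by MTT assay, with a stated time of 72 h (on this read-out lower numbers stand for stronger inhibition of growth and higher numbers for weaker inhibition of growth), compound 1 gives 3200 nM. Compound 2 `O=S(=O)(NCCCNCc1ccc(Cl)cc1)c1cc(C(F)(F)F)cc(C(F)(F)F)c1` carries a chlorine on the benzyl ring, and in this assay compound 2 gives 2800 nM. Going by the values given here, the only measured step, a 1.1-fold lower number from compound 1 to compound 2 (0.06 log units; within the scatter), lies within the scatter, so compound 2 stands beside compound 1 with no real separation between the two.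

Compound 3 `COc1ccccc1CNCCCNS(=O)(=O)c1cc(C(F)(F)F)cc(C(F)(F)F)c1` changes the same ring again: 2-methoxyphenyl in place of 4-chlorophenyl on a saturated chain carbon bound to an amine nitrogen. Among the compounds with values here, the single step that bears on this, from compound 1 to compound 2, left the number essentially unchanged, so a further change on that ring is expected to give no step beyond the scatter in this assay. Compound 3 is therefore estimated at 3000 nM, with a range from 1200 nM to 7500 nM. The expected step of a 1.1-fold higher number from compound 2 to compound 3 (0.03 log units; within the scatter) reflects this flat outlook.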

Compound 3, concentration for 50% growth inhibition: 2400 nM
Compound 3: middle estimate off by 1.3-fold (0.10 log units), on the high side; the range from low to high includes it.
By their numbers in this assay, from the lowest: compounds 3, 2 and 1 (each within the scatter of the next).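

In this assay, exchanging the 4-chlorophenyl for the 2-methoxyphenyl gives a 1.2-fold lower number from compound 2 to compound 3 (0.07 log units; within the scatter), and placing a methoxy on the unsubstituted ring of compound 1 gives a 1.3-fold lower number from compound 1 to compound 3 (0.12 log units; within the scatter). A second kind of substituent, one that brings a hydrogen-bond acceptor where the 4-chlorophenyl has none, therefore also produces no real separation, so all three compounds remain within the scatter of one another. No measurement shown here accounts for this flat result.

Compound 2 and compound 3 differ in both the group and its spot on the ring, so these two changes cannot be told apart. From the compounds shown here alone, whether a carboxylic acid or a second amine on this ring, or a longer chain in the linker, would move the number also remains open.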